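Bromine on the Trimethoxyphenyl Ring of Two Enaminone Series

This account rests on a few compounds, and the source may have more. Where it says the series, first, only, none or still open, it means among the compounds named here.

Of the compounds shown here, three have been measured in a functional assay on HeLa cells (Homo sapiens) for antiproliferative activity, read by sulforhodamine B assay, with a stated time of 48 h; on this read-out higher numbers stand for weaker inhibition and lower numbers for stronger inhibition. Compound 1 `COc1ccc2nc(-c3ccc(N/C=C\C(=O)c4cc(OC)c(OC)c(OC)c4)c(C)c3)sc2c1` gives 16100 nM. Compound 3 `COc1ccc2nc(-c3ccc(N/C=C\C(=O)c4cc(OC)c(OC)c(OC)c4Br)c(C)c3)sc2c1`, which carries bromo in place of hydrogen on an aromatic carbon, gives 13400 nM, so that a 1.2-fold lower number from compound 1 to compound 3 (0.08 log units; within the scatter). Compound 2 `COc1cc(OC)c2sc(-c3ccc(N/C=C\C(=O)c4cc(OC)c(OC)c(OC)c4)cc3)nc2c1` rests on a different core; the difference between the two cores is not broken down here. In this assay compound 2 gives 17800 nM, a number that sits within the scatter of both compound 1 and compound 3.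

Compound 4 `COc1cc(OC)c2sc(-c3ccc(N/C=C\C(=O)c4cc(OC)c(OC)c(OC)c4Br)cc3)nc2c1` has not been measured. It stands to compound 2 as compound 3 stands to compound 1: bromo in place of hydrogen on an aromatic carbon, at a place described in the same words as before, so the change is the same. Going by the values given here, the only earlier reading of this change is the step from compound 1 to compound 3, which lay within the scatter. The step from compound 2 to compound 4 is therefore expected to be of the same small size, a 1.2-fold lower number from compound 2 to compound 4 (0.07 log units; within the scatter). In this assay compound 4 is estimated at 15000 nM, with a likely range from 8000 nM to 30000 nM.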

Compound 4, half-maximal inhibitory concentration: 10300 nM
Beside the measured number, compound 4's estimate is 1.5-fold (0.16 log units) above it; the measured number falls inside the stated range.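

In this assay the new step is a 1.7-fold lower number from compound 2 to compound 4 (0.24 log units; within the scatter), so bromo in place of hydrogen on an aromatic carbon stays within the scatter on this core, as it did on the core of compound 1. Set side by side, the two readings do not differ by more than repeated measurements of this kind allow: the same change on two cores in this assay, a 1.2-fold lower number (0.08 log units; within the scatter) from compound 1 to compound 3 and a 1.7-fold lower number (0.24 log units; within the scatter) from compound 2 to compound 4, 1.4-fold (0.16 log units) apart, within the scatter of two such steps. This shows that the change carries from one of these cores to the other with no detectable difference in the size of its step, but with both steps inside the scatter it does not show that bromo strengthens inhibition on either core, and two cores cannot speak for the whole series.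

The compounds shown leave open whether another group on this aromatic carbon, such as chloro or an amine, would give a step beyond the scatter. They also leave open whether bromo would behave alike on a core bearing a carboxylic acid or a longer chain.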